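Two Primary Amines in Place of One Dimethylamino Group

The source may hold more compounds than are shown below. What is called first, only, known or untested is meant among the compounds shown, and "the series" means these compounds.

Measured so far in an assay on HeLa cells for inhibition of sphingosine-1-phosphate transporter SPNS2 (Mus musculus), read by LC-MS, tested at 2 uM; a higher number here means more inhibition at the concentration tested (going by the name of the read-out), a lower number less inhibition:
compound 1, `CCCCCCCCCCc1ccc(-c2noc(CCCN)n2)cc1`: 67%
compound 2, `CCCCCCCCCCc1ccc(-c2noc(CCCN(C)C)n2)cc1`: 8%
compound 3, `CCCCCCCCCCc1ccc(-c2noc(CC[C@@H](N)C(=O)O)n2)cc1`: 5%

Compound 2 sits second highest of the three numbers in this assay, close to compound 3 and far under compound 1; the gap between compound 2 and compound 3 lies within the scatter, so no order between them is claimed. Compound 4, `CCCCCCCCCCc1ccc(-c2noc([C@@H](N)CCN)n2)cc1`, has not yet been measured. It differs from compound 2 as follows: 1,3-diaminopropyl in place of 3-(dimethylamino)propyl on an aromatic carbon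

For the measured compounds named here, two measured steps bear on this change. The step of a number 59 percentage points lower from compound 1 to compound 2 (beyond the scatter) shows that replacing a primary amine on the chain by dimethylamino costs a great deal; compound 4 reverses that replacement and adds a second amine on the carbon attached to the ring. The step of a number 62 percentage points lower from compound 1 to compound 3 (beyond the scatter) shows that a substituent on that carbon, there a carboxy, also cost a great deal, so the second amine carries some risk. The step of a number 3 percentage points lower from compound 2 to compound 3 (within the scatter) adds nothing further. On balance a large rise is expected, a number 42 percentage points higher from compound 2 to compound 4 (beyond the scatter). Compound 4 is therefore estimated at 50%, within 20% to 78%.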

Compound 4, a percentage reported as inhibition, at one concentration (the size of the read-out at that concentration, not a potency): 14%
For compound 4 the middle estimate is 36 percentage points above the measured one; the measured number lies below the stated range.
By their numbers in this assay, from the lowest: compounds 3, 2 and 4 (each within the scatter of the next); then compound 1.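

In this assay the added amino group on the saturated chain carbon bound to an aromatic carbon gives a number 53 percentage points lower from compound 1 to compound 4 (beyond the scatter) even though the primary amine at the chain end stays in place, so that chain-end amine alone does not keep the inhibition. The 1,3-diaminopropyl group gives a number 6 percentage points higher from compound 2 to compound 4 (within the scatter) and a number 9 percentage points higher from compound 3 to compound 4 (within the scatter) and so cannot be told apart from the other two groups, which means that all three changes shown to the chain of compound 1 end far under it. Nothing given here explains this drop.

The compounds shown leave open whether a longer chain ending in a primary amine, or a guanidine at the chain end, would keep the inhibition seen for compound 1. They also leave open how the opposite configuration at the new stereocentre of compound 4 would behave.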